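The source may hold more compounds than are shown below. What is called first, only, known or untested is meant among the compounds shown, and "the series" means these compounds.

Of the compounds shown here, three have so far been measured in an ADME assay for permeability, using PAMPA, with a stated time of 30 min, at pH 7.4; on this read-out lower numbers stand for lower permeability and higher numbers for higher permeability. Compound 1 `COc1ccc(F)cc1CNCCCNc1ccnc2cc(Cc3ccc(C#N)cc3)ccc12` gives 23 10^-6 cm/s in this assay, and compound 2 `COc1ccc(F)cc1CNCCCNc1ccnc2cc(C3CCCCC3)ccc12` gives 23 10^-6 cm/s, so that no change at the digits printed from compound 1 to compound 2 (within the scatter). Compound 3 `COc1ccc(-c2ccc3c(NCCCNCc4cc(F)ccc4OC)ccnc3c2)cc1` gives 237 10^-6 cm/s, the highest of the three numbers, and it stands well apart from the other two: a 10-fold higher number from compound 1 to compound 3 (1.01 log units; beyond the scatter), and a 10-fold higher number from compound 2 to compound 3 (1.01 log units; beyond the scatter). Both of these large steps concern the group attached to the aromatic carbon of the shared core, where a 4-methoxyphenyl takes the place of a 4-cyanobenzyl or a cyclohexyl.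

Compound 4 `COc1ccc(F)cc1CNCCCNc1ccnc2cc(-c3ccc(C(F)(F)F)cc3)ccc12` keeps that arrangement and differs from compound 3 only further out: trifluoromethyl in place of methoxy on an aromatic carbon. For the measured compounds named here, none of the measured steps touches this position, so no step bears directly on the exchange; the steps that were large, from compound 1 and compound 2 to compound 3, all concern the group on the core itself, which compound 4 retains as a 4-substituted phenyl. On that basis compound 4 is expected to stay near compound 3, with a 1.2-fold lower number from compound 3 to compound 4 (0.07 log units; within the scatter) at most a small step and most likely none beyond the scatter. The estimate for compound 4 in this assay is therefore 200 10^-6 cm/s, with a range from 80 10^-6 cm/s to 500 10^-6 cm/s.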

Compound 4, apparent permeability: 237 10^-6 cm/s
Beside the measured number, compound 4's estimate is 1.2-fold (0.07 log units) below it, within the range that was stated.
By their numbers in this assay, from the lowest: compounds 1 and 2 (each within the scatter of the next); then compounds 3 and 4 (each within the scatter of the next).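

In this assay, trifluoromethyl in place of methoxy on the six-membered aromatic ring of carbon only gives no change at the digits printed from compound 3 to compound 4 (within the scatter), so this place, para to a large group, accepts the exchange of these two groups without a shift beyond the scatter. The large gap from the two lower compounds is therefore not tied to methoxy alone: it appears again as a 10-fold higher number from compound 2 to compound 4 (1.01 log units; beyond the scatter) and as a 10-fold higher number from compound 1 to compound 4 (1.01 log units; beyond the scatter), with 4-(trifluoromethyl)phenyl on the aromatic carbon of the shared core in place of cyclohexyl or 4-cyanobenzyl. Nothing available gives a reason for either the unchanged number or the large gaps.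

The compounds shown leave open whether a hydroxyl, an amine or a carboxylic acid at this same place would also keep the number at this level, and whether a plain phenyl with no group there would do so. They also leave open whether a pyridine ring on the aromatic carbon of the shared core would keep the high number seen with both substituted phenyl groups.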